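The source may hold more compounds than are shown below. What is called first, only, known or untested is meant among the compounds shown, and "the series" means these compounds.

The measured compounds stand as follows. Compound 1 `O=c1[nH]c(Nc2ccccc2F)nc2cc(Cl)ccc12` gives > 25000 nM in an ADME assay on Vero cells (Chlorocebus sabaeus) for cytotoxicity, read by WST assay (on this read-out lower numbers stand for higher toxicity in this test and higher numbers for lower toxicity in this test), and that value is a limit of the assay. Compound 2 `O=c1[nH]c(Nc2cccc(F)c2)nc2cc(Cl)ccc12` gives > 25000 nM in this assay, again a limit. Compound 3 `O=c1[nH]c(Nc2cc(F)cc(F)c2)nc2cc(Cl)ccc12` gives >= 18000 nM in this assay, also a limit.

Compound 2 therefore stands only at a limit in this assay, and the two other values shown are limits as well, so no order among the three can be read. Among the compounds with values here, the single step between measured compounds that differ in one place, a step that the two limits leave unreadable from compound 2 to compound 3, is of unreadable size because both of its ends are limits. What the evidence amounts to is the limit of > 25000 nM in this assay, at which 2 of the 3 values shown sit, and (the limit of >= 18000 nM in this assay, at which 1 of the 3 values shown sits).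

Compound 4 `O=c1[nH]c(Nc2cccc(C(F)(F)F)c2)nc2cc(Cl)ccc12` differs from compound 2 by trifluoromethyl in place of fluoro on an aromatic carbon. Within the data shown here, no measured step bears on a trifluoromethyl entering in place of fluoro, and the one step that exists gives no size at all. With every value shown sitting at a limit, the step that the limit leaves unreadable from compound 2 to compound 4 is expected to be none beyond the scatter. Compound 4 is accordingly expected to give about 30000 nM in this assay, with a range from 12000 nM to 75000 nM, and most likely the assay will again report only a limit.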

Compound 4, half-maximal cytotoxic concentration: > 25000 nM
Compound 4 was reported as a limit (the forecaster's own chance of this, stated with the estimate: 75%); the middle value lies beyond the limit too.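

In this assay compound 4 gives > 25000 nM, which is a limit. No step can be read between compound 2 and compound 4, as both stand only at limits. The compounds shown leave open whether trifluoromethyl in place of fluoro changes the read-out at all, and where the actual value of any of the four compounds lies.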